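Shortening the Butyl Chain of Compound 2

The compounds below may be only part of what the source reports. "The series", "measured", "known", "first", "only" and "open" are said of these compounds alone.

Going by the values given here, in a functional assay on the whole organism (strain Hartley) for inhibition, with Cavia porcellus as the target, with stated times of 15 min and 2 min (a lower number here means that less compound is needed, a higher number that more compound is needed for the effect), compound 2 `CCCCC1([C@H](O)/C=C/C2[C@H](O)CC(=O)[C@@H]2C/C=C\CCCC(=O)O)CCC1` gives 0.00106 mg/kg, the lowest of the three numbers known so far. Compound 3 `CCCCC1([C@H](O)/C=C/C2CCC(=O)[C@@H]2C/C=C\CCCC(=O)O)CCC1` gives 0.0242 mg/kg, and compound 1 `CCCCC1([C@H](O)/C=C/C2CCC(=O)[C@@H]2CCCCSCC(=O)OCC)CCC1` gives 0.909 mg/kg.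

Compound 4 `CCCC1([C@H](O)/C=C/C2[C@H](O)CC(=O)[C@@H]2C/C=C\CCCC(=O)O)CCC1` differs from compound 2 in one place: hydrogen in place of methyl on a saturated chain carbon, three bonds along the chain from a saturated ring carbon. This is hydrogen in place of methyl on a saturated chain carbon, three bonds along the chain from a saturated ring carbon, which turns butyl into propyl.

Among the compounds with values here, no measured step covers this change. The only one available, a 23-fold higher number from compound 2 to compound 3 (1.36 log units; beyond the scatter), swaps a hydroxy for hydrogen on a saturated ring carbon instead. That step is large and shows that a single change can matter in this assay, but it cannot be carried over directly. Since compound 2 holds the lowest number, a modest rise seems likelier than a further fall, and the expected size is smaller than that hydroxy step.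

The estimated change is a 2.8-fold higher number from compound 2 to compound 4 (0.45 log units; beyond the scatter). For compound 4 the expected value is 0.003 mg/kg, with an estimated range from 0.0007 mg/kg to 0.015 mg/kg.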

Compound 4, dose for half-maximal effect: 0.003 mg/kg
Compound 4: middle estimate and measured number agree at the digits printed; the measured number falls inside the stated range.
By their numbers in this assay, from the lowest: compound 2; then compound 4; then compound 3; then compound 1.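

In this assay, going by these compounds alone, the earlier compounds all carry the butyl chain, so they say nothing about its length; here the step to propyl gives a 2.8-fold higher number from compound 2 to compound 4 (0.45 log units; beyond the scatter). Removing this one methyl therefore moves the number beyond the scatter, yet the step is classed as modest, whereas the change on the ring, a 23-fold higher number from compound 2 to compound 3 (1.36 log units; beyond the scatter), is classed as large. Nothing available explains why the shorter chain shifts the number.

Going by these compounds, two single chain lengths cannot show a trend, so it remains open how a longer chain such as pentyl, or a phenyl ring at the end of the chain, would compare with butyl. On these data alone, it is also open whether the same shortening would give a similar step in compound 3, which has hydrogen in place of the ring hydroxy.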